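This account rests on a few compounds, and the source may have more. Where it says the series, first, only, none or still open, it means among the compounds named here.

Within the data shown here, compound 3 `CCCCCCc1cc2c(=O)n(CC3CC3)cnc2s1` is the one compound of the three that gives a number in an ADME assay on HCT-116 cells (Homo sapiens) for cytotoxicity, read by MTT assay, with a stated time of 11 days; on this read-out lower numbers stand for stronger inhibition of growth and higher numbers for weaker inhibition of growth: it shows 17.6 ug/mL. Compound 2 `CCCCCc1cc2c(=O)n(CC3CC3)cnc2s1` is reported only as a limit there, > 100 ug/mL. Compound 1 `CCCCCCCc1cc2c(=O)n(CC#N)cnc2s1` is likewise reported only as a limit, > 100 ug/mL. Among the measured compounds shown here, two of the three values thus sit at the limit of > 100 ug/mL in this assay, at which 2 of the 3 values shown sit, and the one measured step is an at least 5.6-fold lower number from compound 2 to compound 3 (0.75 log units; beyond the scatter).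

Compound 4 `CCCCCCCc1cc2c(=O)n(CC3CC3)cnc2s1` differs from compound 3 by methyl in place of hydrogen on a saturated chain carbon, six bonds along the chain from an aromatic carbon. For the measured compounds named here, the one step that bears on it is the chain lengthening an at least 5.6-fold lower number from compound 2 to compound 3 (0.75 log units; beyond the scatter), a lower bound only. A further lowering or a number within the scatter of compound 3 is expected. Compound 4 is expected to give 8 ug/mL, between 2.5 ug/mL and 30 ug/mL. The expected step is a 2.2-fold lower number from compound 3 to compound 4 (0.34 log units; beyond the scatter).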

Compound 4, concentration for 50% growth inhibition: > 100 ug/mL
Compound 4: only a limit was reported; the forecaster's own chance of this, stated with the estimate: 10%; middle value at least 12-fold (1.09 log units) away from the limit.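

In this assay methyl in place of hydrogen six bonds along the chain from an aromatic carbon reverses the direction of the previous chain step (an at least 5.6-fold lower number from compound 2 to compound 3 (0.75 log units; beyond the scatter)) and gives an at least 5.6-fold higher number from compound 3 to compound 4 (0.75 log units; beyond the scatter). Across compound 2, compound 3 and compound 4 the chain therefore shows no single direction, and the steps to compound 4 from compound 2 and from compound 1 cannot be read. Compound 4 is reported only as a limit, not a number: the limit of > 100 ug/mL in this assay, at which 3 of the 4 values shown sit.

Going by these compounds, whether a longer chain would give a number on this core stays open. So does the effect of a hydroxyl or an amine at the chain end.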